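Taking a methyl group off compound 1

This account rests on a few compounds, and the source may have more. Where it says the series, first, only, none or still open, it means among the compounds named here.

In a functional assay on Malme-3M cells (Homo sapiens) for cytotoxicity, read by MTT assay, with a stated time of 6 days (a higher number here means that more compound is needed for the effect, a lower number that less compound is needed), compound 1 `COC(=O)c1c(-c2cc(OC)cc(OC)c2)oc2ccccc2c1=O` gives > 25 ug/mL as its reading, which is a limit of the assay and not a number. Compound 4 `COc1cc(OC)cc(-c2oc3ccccc3c(=O)c2C(=O)O)c1` differs from it by a single change, hydrogen in place of methyl on an oxygen next to a carbonyl group, or methoxycarbonyl to carboxy hydrogen in place of methyl on an oxygen next to a carbonyl group in full. Within the data shown here, no measured step covers this change. The nearest evidence lies elsewhere, where compound 2 `COC(=O)c1c(-c2ccc([N+](=O)[O-])cc2)oc2cc(OC)ccc2c1=O` gives 1.12 ug/mL and compound 3 `COC(=O)c1c(-c2ccc(O)cc2)oc2cc(OC)ccc2c1=O` gives 20.1 ug/mL in a swap of nitro for hydroxy. That swap produced an 18-fold higher number from compound 2 to compound 3 (1.25 log units; beyond the scatter) and shows that one change can matter, but it sets no direction here. With compound 1 at a limit, the expected change is only a step that the limit leaves unreadable from compound 1 to compound 4 and no clear shift beyond the scatter. In this assay compound 4 is estimated at 30 ug/mL with 12 ug/mL to 80 ug/mL as the expected range.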

Compound 4, concentration for half-maximal effect: > 25 ug/mL
Compound 4 was reported as a limit; the forecaster's own chance of this, stated with the estimate: 65%; the middle value is on the limit's open side.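

Among these compounds, compound 1 and compound 4 both sit at a limit of the assay and not at a number, so no step between them can be read: the limit of > 25 ug/mL in this assay, at which 2 of the 4 values shown sit. As far as these compounds go, whether going from methoxycarbonyl to carboxy shifts the reading at all stays open.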